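This account rests on a few compounds, and the source may have more. Where it says the series, first, only, none or still open, it means among the compounds named here.

Measured compounds:
Compound 1, `COc1cc2c(Oc3ccc(NC(=O)c4cc(-c5ccccc5)ccn4)cc3F)ccnc2cc1OCCCN1CCCC1`, gives 1010 nM in a functional assay on U-87MG ATCC cells (Homo sapiens) for cytotoxicity, read by MTT assay, with a stated time of 72 h; a higher number here means a weaker inhibitor, a lower number a stronger inhibitor.
Compound 2, `COc1cc2c(Oc3ccc(NC(=O)c4cc(-c5ccccc5F)ccn4)cc3F)ccnc2cc1OCCCN1CCCC1`, gives 610 nM in this assay.
Compound 3, `COc1cc2c(Oc3ccc(NC(=O)c4nccc(-c5ccc(F)cc5)n4)cc3F)ccnc2cc1OCCCN1CCCCC1`, gives "not determined" (no result reported) in this assay.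

Compound 1 and compound 2 differ by fluoro in place of hydrogen on an aromatic carbon, and that change made a 1.7-fold lower number from compound 1 to compound 2 (0.22 log units; within the scatter). Compound 3 has no number in this assay; the difference between its core and that of compound 1 is not broken down here. Compound 4, `COc1cc2c(Oc3ccc(NC(=O)c4nccc(-c5ccc(F)cc5F)n4)cc3F)ccnc2cc1OCCCN1CCCCC1`, differs from compound 3 by fluoro in place of hydrogen on an aromatic carbon, the same kind of change as from compound 1 to compound 2, though here the entering group also sits meta to a fluoro group (1 heavy atom). With no number for compound 3, the expectation for compound 4 in this assay rests on compound 1 at 1010 nM and compound 2 at 610 nM, which share much of the structure. Compound 4 is therefore estimated at 700 nM, expected to lie between 200 nM and 2500 nM.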

Compound 4, half-maximal inhibitory concentration: 780 nM
For compound 4 the middle estimate is 1.1-fold (0.05 log units) below the measured one, within the range that was stated.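

Going by these compounds alone, no step from compound 3 to compound 4 can be read, though compound 4 gives 780 nM in this assay. From the compounds shown here alone, what going from 4-fluorophenyl to 2,4-difluorophenyl does here stays open. No further evidence bears on this result.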